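Swapping a Hydroxyethyl Tail for a Triethylpyrazolyl Group

The source may hold more compounds than are shown below. What is called first, only, known or untested is meant among the compounds shown, and "the series" means these compounds.

Measured compounds:
compound 1 `CC(C)(C)c1ccc(C(=O)N2CCC3(CC2)C(=O)N(CC(=O)N2CCC(CCO)CC2)CN3c2ccccc2)cc1` — 2600 nM
compound 2 `CC(C)(C)c1ccc(C(=O)N2CCC3(CC2)C(=O)N(CC(=O)NCCCCO)CN3c2ccccc2)cc1` — 19200 nM

In an assay on HEK293 cells for displacement of a labelled ligand from NPC1-like intracellular cholesterol transporter 1 (Homo sapiens) (a lower number here means a stronger inhibitor, a higher number a weaker inhibitor), compound 1 gives 2600 nM, the lower of the two numbers recorded, while compound 2 gives 19200 nM. Going by the values given here, the single measured step, a 7.4-fold higher number from compound 1 to compound 2 (0.87 log units; beyond the scatter), shows that changes at the amide end of the shared core can move the number well beyond the scatter.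

Compound 3 `CCc1nn(CC)c(C2CCN(C(=O)CN3CN(c4ccccc4)C4(CCN(C(=O)c5ccc(C(C)(C)C)cc5)CC4)C3=O)CC2)c1CC` keeps the core of compound 1 but differs in 1,3,4-triethyl-1H-pyrazol-5-yl in place of 2-hydroxyethyl on a saturated ring carbon. Among the compounds with values here, no measured step tests this kind of exchange directly: the one known step replaced the whole ring-bearing amine, whereas here the ring stays and only the group on its saturated ring carbon changes. Within the data shown here, with no closer precedent, the step of a 1.3-fold lower number from compound 1 to compound 3 (0.11 log units; within the scatter) is expected to stay small. Compound 3 is therefore expected to give about 2000 nM in this assay, with a likely range from 500 nM to 8000 nM.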

Compound 3, half-maximal inhibitory concentration: 4600 nM
Compound 3: middle estimate off by 2.3-fold (0.36 log units), on the low side; low and high end bracket the measured number.
By their numbers in this assay, from the lowest: compounds 1 and 3 (each within the scatter of the next); then compound 2.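

In this assay, the saturated ring carbon three ring bonds from the ring nitrogen accepts a far larger group without a shift beyond the scatter: 2-hydroxyethyl, with 3 heavy atoms and no ring, gives way to 1,3,4-triethyl-1H-pyrazol-5-yl, with 11 heavy atoms and a five-membered aromatic ring (a 1.8-fold higher number from compound 1 to compound 3 (0.25 log units; within the scatter)). The exchange also removes the hydrogen-bond donor of 2-hydroxyethyl, yet the two compounds still read alike, so for this pair neither the donor nor the smaller size of the tail is needed to keep the number within the scatter. Nothing available here accounts for this result.

Going by these compounds, because the size, the ring and the donor all change in one step, their separate contributions remain unknown. A plain ethyl group, a carboxylic acid or an amine on this ring carbon could help separate them.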